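The source may report more compounds than this note shows. Statements on the series, on what has been measured and on what is new or still open speak of the compounds shown alone.

Two ureas sharing one core have been measured in an assay on microsomes from intestine for inhibition of acyl-CoA:cholesterol acyltransferase (Oryctolagus cuniculus) (a lower number here means a stronger inhibitor, a higher number a weaker inhibitor), so far. Compound 1 `Cc1cc(C)c(NC(=O)N(Cc2ccc(-c3n[nH]c(C)n3)cc2)C2CCCCCC2)c(C)c1` gives 120 nM in this assay, and compound 2 `Cc1cc(C)c(NC(=O)N(Cc2ccc(-n3cccn3)cc2)C2CCCCCC2)c(C)c1` gives 70 nM. The step of a 1.7-fold lower number from compound 1 to compound 2 (0.23 log units; within the scatter) is the only one recorded, and it lies within the scatter, so on the two numbers compound 2 stands at the lower value without a difference that counts. Compound 3 `Cc1cc(C)c(NC(=O)N(Cc2ccc(-c3cc[nH]n3)cc2)C2CCCCCC2)c(C)c1` is not yet measured in this assay. Compared with compound 2, the change is 1H-pyrazol-3-yl in place of 1H-pyrazol-1-yl on an aromatic carbon, the same atoms joined differently. For the measured compounds named here, the one measured step, from compound 1 to compound 2, also exchanged one azole for another and moved the number only within the scatter, which suggests that this exchange too should stay within the scatter. The estimated step is therefore a 1.3-fold higher number from compound 2 to compound 3 (0.11 log units; within the scatter). For compound 3 the expected value in this assay is 90 nM, with a range from 40 nM to 200 nM.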

Compound 3, half-maximal inhibitory concentration: 52 nM
Compound 3: the middle estimate sits 1.7-fold (0.24 log units) above what was measured; the measured number falls inside the stated range.
By their numbers in this assay, from the lowest: compounds 3, 2 and 1 (each within the scatter of the next, the first and the last beyond it).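

In this assay, 1H-pyrazol-3-yl in place of 1H-pyrazol-1-yl on the aromatic carbon para to a large group gives a 1.3-fold lower number from compound 2 to compound 3 (0.13 log units; within the scatter), so the two ways of joining the same ring are not told apart here, although the hydrogen-bond donor count goes from 0 to 1. 1H-pyrazol-3-yl in place of 5-methyl-1H-1,2,4-triazol-3-yl gives a 2.3-fold lower number from compound 1 to compound 3 (0.36 log units; beyond the scatter), a modest step and the first in the series to pass the scatter, but ring and methyl change together, so neither can be credited alone. Nothing measured bears on why these numbers fall as they do.

A 5-methyl-1H-pyrazol-3-yl group would separate the methyl from the ring change. Whether this position needs an azole at all remains open, as the compounds shown include no carboxylic acid, amine or plain phenyl there.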